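Replacing 2-fluorobenzyl with cyclohexylmethyl on compound 3

This account rests on a few compounds, and the source may have more. Where it says the series, first, only, none or still open, it means among the compounds named here.

In an in vitro ADME assay on microsomes from liver (Homo sapiens) for metabolic stability, tested at 1 uM (on this read-out higher numbers stand for a longer-lived compound and lower numbers for a shorter-lived compound), compound 1 `CS(=O)(=O)Nc1ccc2c(c1)S(=O)(=O)N=C(C1=C(O)[C@@H]3[C@H]4CC[C@H](C4)[C@@H]3N(Cc3ccccc3F)C1=O)N2` gives > 1 h, which is a limit of the assay and not a number. Compound 2 `CS(=O)(=O)Nc1ccc2c(c1)S(=O)(=O)N=C(C1=C(O)[C@@H]3[C@H]4CC[C@H](C4)[C@@H]3N(Cc3ccc(F)c(F)c3F)C1=O)N2` gives > 1 h, again a limit. Compound 3 `CS(=O)(=O)Nc1ccc2c(c1)S(=O)(=O)N=C(C1=C(O)[C@@H]3[C@@H]4CC[C@@H](C4)[C@@H]3N(Cc3ccccc3F)C1=O)N2` gives > 1 h, also a limit, and this is all that is known of where it stands.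

Compound 4 `CS(=O)(=O)Nc1ccc2c(c1)S(=O)(=O)N=C(C1=C(O)[C@@H]3[C@@H]4CC[C@@H](C4)[C@@H]3N(CC3CCCCC3)C1=O)N2` differs from compound 3 as follows: cyclohexyl in place of 2-fluorophenyl on a saturated chain carbon bound to an amide-type nitrogen in a ring. In words, cyclohexyl stands in place of 2-fluorophenyl on a saturated chain carbon bound to an amide-type nitrogen in a ring.

Going by the values given here, two measured steps bear on this. Among the compounds with values here, the one that changes the same group is a step that the two limits leave unreadable from compound 1 to compound 2, and the one that changes configuration alone is a step that the two limits leave unreadable from compound 1 to compound 3. Neither gives a size, and neither swaps an aromatic ring for a non-aromatic one, so the data point in no direction. In this assay no change beyond the usual scatter is therefore expected, and the estimated step is a step that the limit leaves unreadable from compound 3 to compound 4. For compound 4 the estimated half-life is 1.2 h, with an expected range from 0.5 h to 3 h.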

Compound 4, half-life: 0.25 h
Compound 4: middle estimate off by 4.8-fold (0.68 log units), on the high side; the measured number lies below the stated range.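

In this assay compound 3 gives > 1 h, which is a limit of the assay and not a number. Going by these compounds alone, putting cyclohexyl in place of 2-fluorophenyl gives the first readable step at this position, an at least 4.0-fold lower number from compound 3 to compound 4 (0.60 log units; beyond the scatter), so the group held here can clearly change the half-life. The earlier steps, including the change of fluorine pattern and the change of configuration, cannot be read because their values all sit at one limit: the limit of > 1 h in this assay, at which 3 of the 4 values shown sit.

The compounds shown leave open whether the shorter half-life goes with the loss of the aromatic ring or with the loss of the fluorine, a question that an unsubstituted phenyl in the same place would help to separate. Going by these compounds, it also remains open whether cyclohexyl would give a similar step on the configuration of compound 1.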